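A few compounds are considered here, and "the series" means these few. Any claim that something is new, unique, unknown or untested is made for them only; others in the source may bear on it.

The step under consideration leads from compound 3 `CC1=C(C(=O)OCC(F)(F)F)C(c2cccs2)NC(=O)N1` to compound 4 `CC1=C(C(=O)OCC(F)(F)F)C(c2ccco2)NC(=O)N1`. In an assay on cells for displacement of a labelled ligand from adenosine receptor A1 (Homo sapiens), read by radioligand binding, with a stated time of 60 min, tested at 1 uM (a lower number here means less inhibition, a higher number more inhibition at the concentration tested (going by the name of the read-out)), compound 3 gives 3%, the lowest of the two single numbers available; its nearest neighbour is compound 2 `CC1=C(C(=O)OCC(F)(F)F)C(c2ccoc2)NC(=O)N1`, which gives 13%. Compound 1 `CC1=C(C(=O)OC(C)C(F)(F)F)C(c2ccco2)NC(=O)N1`, measured twice, gives 1%; 1% (2 entries) each time.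

The change is furan-2-yl in place of thiophen-2-yl on a saturated ring carbon. For the measured compounds named here, one measured step bears on it: a number 10 percentage points lower from compound 2 to compound 3 (within the scatter), which shows that swapping one five-membered aromatic ring for another at this position did nothing beyond the scatter. Compound 1 also carries a furan-2-yl ring, though it differs from compound 4 elsewhere in the structure, and its values are low as well. Going by the values given here, no step between compound 1 and compound 4 has been computed, so only the values themselves can be compared.

Taken together, an essentially flat step is expected: a number 1 percentage points higher from compound 3 to compound 4 (within the scatter). Compound 4 is therefore estimated at 4%, with a range from -5% to 15%.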

Compound 4, a percentage reported as inhibition, at one concentration (the size of the read-out at that concentration, not a potency): 10%
For compound 4 the middle estimate is 6 percentage points below the measured one; measured number inside the range.
By their numbers in this assay, from the lowest: compounds 3, 4 and 2 (each within the scatter of the next).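

Measured in this assay on the shared core, replacing thiophen-2-yl with furan-2-yl gives a number 7 percentage points higher from compound 3 to compound 4 (within the scatter) and so exchanging the sulfur of the ring for oxygen produces no change that can be told apart here. Moving the point of attachment, with furan-2-yl in place of furan-3-yl, gives a number 3 percentage points lower from compound 2 to compound 4 (within the scatter) and so this change also stays inside the usual variation. With this result, compound 2, compound 3 and compound 4 are all joined by steps within the scatter, so none of these three rings can be ranked above another at this saturated ring carbon.

From the compounds shown here alone, all three are five-membered aromatic rings with one hetero atom, so the effect of a phenyl ring, an amine or a carboxylic acid on this carbon remains open. No supporting measurement is available to explain these numbers.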